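Aryl sulfone variation on a shared core: chloro to cyano

A few compounds are considered here, and "the series" means these few. Any claim that something is new, unique, unknown or untested is made for them only; others in the source may bear on it.

Of the compounds shown here, three sharing one core have been measured in an assay on isolated protein for displacement of a labelled ligand from metabotropic glutamate receptor 5 (Homo sapiens), with a stated time of 60 min, tested at 1 uM; a lower number here means less inhibition, a higher number more inhibition at the concentration tested (going by the name of the read-out). Compound 1 `Cc1ccc2ncc(S(=O)(=O)c3ccc(C)c(F)c3)c(N3CCC(C)CC3)c2c1` gives 91%, compound 2 `COc1ccc(S(=O)(=O)c2cnc3ccc(C)cc3c2N2CCC(C)CC2)cc1Cl` gives 93%, and compound 3 `Cc1ccc2ncc(S(=O)(=O)c3cccc(Cl)c3)c(N3CCC(C)CC3)c2c1` gives 91%. Compound 3 stands level with compound 1, the two together being the lowest of the three numbers, with a number 2 percentage points higher from compound 1 to compound 2 (within the scatter), no change at the digits printed from compound 1 to compound 3 (within the scatter) and a number 2 percentage points lower from compound 2 to compound 3 (within the scatter) all within the scatter. Compound 4 `Cc1ccc2ncc(S(=O)(=O)c3cccc(C#N)c3)c(N3CCC(C)CC3)c2c1` differs from compound 3 by cyano in place of chloro on an aromatic carbon. Among the compounds with values here, the steps that bear on it are the three above, each changing substituents on the same aryl sulfone, and none moved the read-out beyond the scatter. Compound 4 is therefore expected to show a number 3 percentage points lower from compound 3 to compound 4 (within the scatter), no more than the scatter. The estimate for compound 4 in this assay is 88%, with a range from 72% to 97%.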

Compound 4, a percentage reported as inhibition, at one concentration (the size of the read-out at that concentration, not a potency): 52%
Estimate against measurement, compound 4: 36 percentage points above; measured number below the stated range.
By their numbers in this assay, from the lowest: compound 4; then compounds 1, 3 and 2 (each within the scatter of the next).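

In this assay the aryl group on the sulfone proves sensitive to change after all: with cyano in place of chloro there is a number 39 percentage points lower from compound 3 to compound 4 (beyond the scatter), whereas the earlier changes on this ring all stayed within the scatter. The comparisons with the other two aryl groups agree, with a number 41 percentage points lower from compound 2 to compound 4 (beyond the scatter) and a number 39 percentage points lower from compound 1 to compound 4 (beyond the scatter), so 3-cyanophenyl alone stands apart among these four compounds. Nothing available here accounts for this drop. Still open, as far as these compounds go, is whether the drop is particular to cyano, or would also follow from an amide or a carboxylic acid on the same aromatic carbon.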